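The source may report more compounds than this note shows. Statements on the series, on what has been measured and on what is new or still open speak of the compounds shown alone.

Going by the values given here, in an assay on CHO cells for displacement of a labelled ligand from adenosine receptor A2b (Homo sapiens), read by scintillation counting, with a stated time of 75 min, in the presence of a further agent that is not named here (a lower number here means a stronger inhibitor, a higher number a weaker inhibitor), compound 2 `CCCn1c(=O)[nH]c2nc(-c3ccc(S(=O)(=O)N4CCN(C)CC4)cc3)[nH]c2c1=O` gives 48.2 nM, the higher of the two numbers so far; its nearest neighbour is compound 1 `CCCn1c(=O)[nH]c2nc(-c3ccc(S(=O)(=O)N4CCN(c5ccc(Br)cc5)CC4)cc3)[nH]c2c1=O`, which gives 0.0835 nM. Among the compounds with values here, the one measured step, a 580-fold higher number from compound 1 to compound 2 (2.76 log units; beyond the scatter), is methyl in place of 4-bromophenyl on an amine nitrogen in a ring. Compound 3 `CCCn1c(=O)[nH]c2nc(-c3ccc(S(=O)(=O)N4CCN(c5cccc(Br)c5)CC4)cc3)[nH]c2c1=O` reverses that change with a 3-bromophenyl instead of a 4-bromophenyl: 3-bromophenyl in place of methyl on an amine nitrogen in a ring. Because a 580-fold higher number from compound 1 to compound 2 (2.76 log units; beyond the scatter) was large, a large downward step in this assay is expected for compound 3. The estimate for compound 3 is 0.2 nM, range 0.04 nM to 1 nM. The expected step is a 240-fold lower number from compound 2 to compound 3 (2.38 log units; beyond the scatter).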

Compound 3, inhibition constant: 0.234 nM
The estimate for compound 3 lay 1.2-fold (0.07 log units) below the measured number, within the range that was stated.
By their numbers in this assay, from the lowest: compound 1; then compound 3; then compound 2.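

In this assay, the large gain over methyl on this amine nitrogen in a ring does not depend on the 4-bromophenyl: 3-bromophenyl in place of methyl gives a 210-fold lower number from compound 2 to compound 3 (2.31 log units; beyond the scatter) on its own. The site of the bromine still counts, though much less, with 3-bromophenyl in place of 4-bromophenyl giving a 2.8-fold higher number from compound 1 to compound 3 (0.45 log units; beyond the scatter) in this series. Nothing available here accounts for either step. Open, going by these compounds, is how much of the gain belongs to the phenyl ring and how much to the bromine. Unsubstituted phenyl, 3-chlorophenyl or benzyl on this nitrogen would separate the two.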